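A second chloro on compound 2

The source may hold more compounds than are shown below. What is called first, only, known or untested is meant among the compounds shown, and "the series" means these compounds.

In a functional assay on MDA-MB-231 cells (Homo sapiens) for antiproliferative activity, read by MTT assay, with a stated time of 72 h (a higher number here means a weaker inhibitor, a lower number a stronger inhibitor), compound 2 (`NC1=NC2(CCSCC2)N(OCCCOc2cccc(Cl)c2)C(N)=N1`) gives 130 nM and sits in the middle of three values. Compound 1 (`NC1=NC2(CCSCC2)N(OCCCOc2ccc(Cl)c(Cl)c2)C(N)=N1`) gives 10 nM and compound 3 (`NC1=NC2(CCOCC2)N(OCCCOc2ccccc2Cl)C(N)=N1`) gives 1430 nM (though compound 3 differs from compound 2 in more than one place). Compound 4 (`NC1=NC2(CCSCC2)N(OCCCOc2cccc(Cl)c2Cl)C(N)=N1`) goes from 3-chlorophenyl to 2,3-dichlorophenyl (chloro in place of hydrogen on an aromatic carbon) with the new chloro ortho to a chloro group. Among the compounds with values here, the one measured step that bears on this is the reverse kind of change, hydrogen in place of chloro (a 13-fold higher number from compound 1 to compound 2 (1.11 log units; beyond the scatter)) and large, but compound 1 carries its second chloro on a different aromatic carbon. A smaller step in the same favourable direction is therefore expected, toward a lower number (a 2.9-fold lower number from compound 2 to compound 4 (0.46 log units; beyond the scatter)). The estimate for compound 4 is 45 nM (expected range 12 nM to 180 nM).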

Compound 4, half-maximal inhibitory concentration: 1 nM
Beside the measured number, compound 4's estimate is 45-fold (1.65 log units) above it; measured number below the stated range.
By their numbers in this assay, from the lowest: compound 4; then compound 1; then compound 2; then compound 3.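

In this assay a chloro placed ortho to a chloro group gives a large change (a 130-fold lower number from compound 2 to compound 4 (2.11 log units; beyond the scatter)), so this aromatic carbon is highly sensitive to this substitution. The placement of the second chloro also matters, since 2,3-dichlorophenyl in place of 3,4-dichlorophenyl gives a further change (a 10-fold lower number from compound 1 to compound 4 (1.00 log units; beyond the scatter)). Nothing measured here explains why this placement gives the lower number.

The compounds shown leave open whether chlorine itself is needed on this carbon, which a fluoro, methyl or methoxy group there would test. They also leave open whether the same change holds on the core of compound 3.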